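A few compounds are considered here, and "the series" means these few. Any claim that something is new, unique, unknown or untested is made for them only; others in the source may bear on it.

Measured so far: compound 1 `Cc1cc(-c2nc3cc(F)ccc3o2)ccc1NC(=O)CCl` and compound 2 `O=C(CCl)Nc1ccc(-c2nc3cc(F)ccc3o2)cc1`.

In a functional assay on MCF7 cells (Homo sapiens) for cytotoxicity, read by MTT assay, with a stated time of 24 h (a lower number here means a stronger inhibitor, a higher number a weaker inhibitor), compound 1 gives only a limit of the assay, > 100000 nM, and no number. In this assay compound 2 gives 3260 nM. Among the compounds with values here, the one measured step, an at least 30-fold lower number from compound 1 to compound 2 (1.48 log units; beyond the scatter), concerns the methyl on the aromatic carbon and nothing else; how much of it the fluoro carries cannot be read from it, and the limit of > 100000 nM in this assay, at which 1 of the 2 values shown sits, means that the true size of that step is itself open.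

Compound 3 `Cc1cc(-c2nc3ccccc3o2)ccc1NC(=O)CCl` differs from compound 1 by hydrogen in place of fluoro on an aromatic carbon, which leaves the methyl of compound 1 in place. Within the data shown here, no measured step touches the fluoro, so the change from compound 1 to compound 3 has nothing in the numbers to set its direction or size, and the expectation is of no step beyond the scatter in this assay. Since compound 1 stands at a limit, compound 3 is expected to sit near that limit as well. Compound 3 is estimated at 100000 nM, between 20000 nM and 400000 nM, a step of a number no higher from compound 1 to compound 3 (the limit leaves the size open) expected, with a fair chance that only a limit is reported again.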

Compound 3, half-maximal inhibitory concentration: 29800 nM
Compound 3: the middle estimate sits 3.4-fold (0.53 log units) above what was measured; measured number inside the range.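

The fluoro on the aromatic ring now has a measured step of its own: replacing it with hydrogen, with the methyl of compound 1 kept in place, gives an at least 3.3-fold lower number from compound 1 to compound 3 (0.52 log units; beyond the scatter) in this assay. Within the data shown here, the earlier step concerned only the methyl, so this is the first reading at this position, and it shows that, in the presence of that methyl, the number changes beyond the scatter when the fluoro goes and that the hydrogen compound has the lower number. Only the direction and a smallest possible size can be read, because compound 1 is a limit and not a number: the limit of > 100000 nM in this assay, at which 1 of the 3 values shown sits.

Compound 2 and compound 3 differ in two places, so the compounds shown do not tell whether removing the fluoro would have the same effect without the methyl, or how the two changes combine. From the compounds shown here alone, how a chlorine, a methoxy group or a nitrile on the same aromatic carbon would read in this assay also remains open, as does whether any such change would take the number past that of the hydrogen in compound 3.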